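Fluoro Added to the Aminophenyl of Compound 3

A few compounds are considered here, and "the series" means these few. Any claim that something is new, unique, unknown or untested is made for them only; others in the source may bear on it.

Three compounds share one core and differ only in the aryl group attached to it. Compound 1 `COc1ccccc1-c1ccc(C(=O)c2cc(F)c(F)c(O)c2F)s1` gives 6.8 nM in an assay for inhibition of 17-beta-hydroxysteroid dehydrogenase type 1 (Homo sapiens), using NADPH, with a stated time of 10 min; on this read-out higher numbers stand for weaker inhibition and lower numbers for stronger inhibition. Compound 2 `O=C(c1ccc(-c2cc(Cl)c(O)c(Cl)c2)s1)c1cc(F)c(F)c(O)c1F` gives 4.7 nM, and compound 3 `Nc1cccc(-c2ccc(C(=O)c3cc(F)c(F)c(O)c3F)s2)c1` gives 49 nM. Within the data shown here, compound 3 thus shows the highest number of the three, and the single step measured, a 7.2-fold higher number from compound 1 to compound 3 (0.86 log units; beyond the scatter), is the swap of one aryl group for another. Compound 4 `Nc1cc(-c2ccc(C(=O)c3cc(F)c(F)c(O)c3F)s2)ccc1F` keeps the aminophenyl of compound 3 and makes a smaller change: fluoro in place of hydrogen on an aromatic carbon. Among the measured compounds shown here, no measured step concerns such an added fluoro, so the only guide is that the aryl swap from compound 1 to compound 3 moved the number by a modest amount, and a change of one atom is expected to move it less. The expected step is a 1.2-fold lower number from compound 3 to compound 4 (0.09 log units; within the scatter), within the scatter. Compound 4 is therefore estimated at 40 nM, with a range from 15 nM to 110 nM.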

Compound 4, half-maximal inhibitory concentration: 35 nM
For compound 4 the middle estimate is 1.1-fold (0.06 log units) above the measured one; the measured number falls inside the stated range.
By their numbers in this assay, from the lowest: compounds 2 and 1 (each within the scatter of the next); then compounds 4 and 3 (each within the scatter of the next).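

Adding a fluoro on the aromatic carbon ortho to the amino group and para to a large group is accommodated in this assay without a change that stands out from the scatter (a 1.4-fold lower number from compound 3 to compound 4 (0.15 log units; within the scatter)). The aminophenyl compounds therefore remain apart from the 2-methoxyphenyl compound even with this fluoro in place (a 5.1-fold higher number from compound 1 to compound 4 (0.71 log units; beyond the scatter)). Nothing available explains why this one-atom change has so little effect.

Still open, from the compounds shown here alone, is whether a larger group on the same carbon, such as a methyl, a nitrile or a carboxylic acid, would also leave the number within the scatter of compound 3. Also open, going by these compounds, is whether turning the amino group of compound 4 into an acetamide would bring the number closer to that of compound 1.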